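Aryl variation on the chromenedione series: compound 4

A few compounds are considered here, and "the series" means these few. Any claim that something is new, unique, unknown or untested is made for them only; others in the source may bear on it.

The shared core carries a para-substituted or methylated phenyl next to the ring oxygen. Compound 1 `CCC1=C(O)c2c(oc(-c3ccc(SC)cc3)cc2=O)C(CC)(CC)C1=O` bears a 4-(methylsulfanyl)phenyl; in a functional assay on KB cells (Homo sapiens) for antiproliferative activity, read by sulforhodamine B assay, with a stated time of 3 days (a higher number here means that more compound is needed for the effect, a lower number that less compound is needed), compound 1 reaches only the limit > 52.1 uM. Compound 2 `CCC1=C(O)c2c(oc(-c3ccc(Br)cc3)cc2=O)C(CC)(CC)C1=O` carries 4-bromophenyl; in this assay compound 2 likewise gives only the limit > 48.1 uM. The step that the two limits leave unreadable from compound 1 to compound 2 is therefore not readable. Among the compounds with values here, compound 3 `CCC1=C(O)c2c(oc(-c3cc(C)c(C)cc3C)cc2=O)C(CC)(CC)C1=O`, with 2,4,5-trimethylphenyl, gives 8.2 uM in this assay and is the only member of the three with a number rather than a limit. The steps of an at least 6.3-fold lower number from compound 1 to compound 3 (0.80 log units; beyond the scatter) and an at least 5.8-fold lower number from compound 2 to compound 3 (0.76 log units; beyond the scatter) both lie beyond the scatter and point the same way, toward the trimethylated aryl.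

Compound 4 `CCC1=C(O)c2c(oc(-c3cccc(C)c3C)cc2=O)C(CC)(CC)C1=O` differs from compound 3 by 2,3-dimethylphenyl in place of 2,4,5-trimethylphenyl on an aromatic carbon. Within the data shown here, no measured step changes only the count or placing of methyls on the aryl; the measured steps replace the whole aryl and bear only indirectly. An expectation for compound 4 in this assay is thus a number near that of compound 3, with a small loss allowed: the estimated step of a 1.5-fold higher number from compound 3 to compound 4 (0.17 log units; within the scatter) is expected to stay within or just beyond the scatter. Compound 4 is estimated at 12 uM, with a range from 4 uM to 40 uM.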

Compound 4, concentration for half-maximal effect: 3.1 uM
Estimate against measurement, compound 4: 3.9-fold (0.59 log units) above; measured number outside the range, below it.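

On the aromatic carbon next to the ring oxygen, 2,3-dimethylphenyl in place of 2,4,5-trimethylphenyl gives a 2.6-fold lower number from compound 3 to compound 4 (0.42 log units; beyond the scatter) in this assay, so the third methyl of compound 3 is not needed for a measured number at this position, and the smaller methylated aryl reads better. Against the two other aryls the gap is wider, with an at least 15-fold lower number from compound 2 to compound 4 (1.19 log units; beyond the scatter) and an at least 16-fold lower number from compound 1 to compound 4 (1.22 log units; beyond the scatter), and across the four compounds the methylated aryls of compound 3 and compound 4 give numbers while 4-bromophenyl and 4-(methylsulfanyl)phenyl do not, with no compound shown going against this. Both of these wider steps start from limits rather than numbers, so their true size stays unknown, for compound 2 and then compound 1: the limit of > 48.1 uM in this assay, at which 1 of the 4 values shown sits, and the limit of > 52.1 uM in this assay, at which 1 of the 4 values shown sits.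

Within the data shown here, whether the gain follows the count of methyls or their placing stays open, as the one step from compound 3 to compound 4 changes both together. Also open, going by these compounds, is how a dimethylamino group or a carboxylic acid on this aryl would read, or an ethyl chain in place of one of its methyls.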